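The source may report more compounds than this note shows. Statements on the series, on what has been measured and on what is new or still open speak of the compounds shown alone.

Values in a functional assay on A20 cells (Mus musculus) for inhibition, with stated times of 1 h, 16 h and 24 h; a lower number here means a stronger inhibitor, a higher number a weaker inhibitor:
- compound 1 `N#CC1(NC(=O)[C@@H]2C[C@@H](S(=O)(=O)c3ccccc3)C[C@H]2C(=O)N2CCOCC2)CC1`: 12 nM
- compound 2 `N#CC1(NC(=O)[C@@H]2C[C@@H](S(=O)(=O)c3ccccc3)C[C@H]2C(=O)N2CCCCC2)CC1`: 5 nM
- compound 3 `CN1CCN(C(=O)[C@@H]2C[C@H](S(=O)(=O)c3ccccc3)C[C@H]2C(=O)NC2(C#N)CC2)CC1`: not yet measured

Of the two measured compounds, compound 2 has the lower number, 5 nM. The change to compound 3 is 4-methylpiperazin-1-yl in place of piperidin-1-yl on a carbonyl carbon. Going by the values given here, only one measured step bears on this place: a 2.4-fold lower number from compound 1 to compound 2 (0.38 log units; beyond the scatter), with piperidin-1-yl in place of morpholin-4-yl. Among the compounds with values here, no measurement yet covers 4-methylpiperazin-1-yl, so the expectation in this assay rests on that single step. A similarly modest move towards a higher number is expected, and the estimated step is a 2.0-fold higher number from compound 2 to compound 3 (0.30 log units; within the scatter). Compound 3 is expected at 10 nM, with an estimated range of 3 nM to 35 nM.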

Compound 3, half-maximal inhibitory concentration: 17 nM
Compound 3: the middle estimate sits 1.7-fold (0.23 log units) below what was measured; the range from low to high includes it.
By their numbers in this assay, from the lowest: compound 2; then compounds 1 and 3 (each within the scatter of the next).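

In this assay, 4-methylpiperazin-1-yl on the carbonyl carbon gives (a 3.4-fold higher number from compound 2 to compound 3 (0.53 log units; beyond the scatter)), so piperidin-1-yl now stands apart from both other six-membered rings at this place, with no compound shown going against that. Morpholin-4-yl and 4-methylpiperazin-1-yl are not separated (a 1.4-fold higher number from compound 1 to compound 3 (0.15 log units; within the scatter)), so the extra methyl-bearing ring nitrogen offers no gain over the ring of compound 1. Nothing shown accounts for this difference. Open, on these data alone, is whether an open-chain diethylamino group or a 4-hydroxypiperidin-1-yl ring on the same carbonyl carbon would match compound 2.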